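Ethyl in place of the amine hydrogen of compound 2

The compounds below may be only part of what the source reports. "The series", "measured", "known", "first", "only" and "open" are said of these compounds alone.

Of the compounds shown here, two have numbers so far in a physicochemical assay for lipophilicity, read by HPLC, using the shake flask method; a higher number here means a more lipophilic compound, a lower number a more polar compound. Compound 1 `C/C(=N\C#N)N(Cc1ccc(Cl)nc1)C(C)C` gives 1.46, and compound 2 `C/C(=N\C#N)NCc1ccc(Cl)nc1` gives 1.07, the lower of the two numbers. Compound 3 `CCN(Cc1ccc(Cl)nc1)/C(C)=N/C#N` has not yet been measured. Its structure departs from that of compound 2 by ethyl in place of hydrogen on an amine nitrogen.

Among the measured compounds shown here, only one measured step bears on this change: a number 0.39 log units lower from compound 1 to compound 2 (beyond the scatter). That step puts hydrogen in place of isopropyl on an amine nitrogen, so it removes a chain where the new change adds one. A rise in this assay is therefore expected, of modest size and probably smaller than the measured step. For the measured compounds named here, no ethyl compound has been measured, and a single step cannot fix the size, so the rise may not clear the usual scatter. The estimate amounts to an expected a number 0.18 log units higher from compound 2 to compound 3 (within the scatter). For compound 3 the expected value is 1.25, with an estimated range of 0.95 to 1.55.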

Compound 3, partition coefficient: 1.19
Estimate against measurement, compound 3: 0.06 log units above; the range from low to high includes it.
By their numbers in this assay, from the lowest: compounds 2, 3 and 1 (each within the scatter of the next, the first and the last beyond it).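

On the amine nitrogen, ethyl in place of hydrogen gives in this assay a number 0.12 log units higher from compound 2 to compound 3 (within the scatter) and thus adds no separation that can be read from this single change. Read against the branched group, hydrogen in place of methyl on a saturated chain carbon bound to an amine nitrogen and a saturated chain carbon gives a number 0.27 log units lower from compound 1 to compound 3 (within the scatter) and so leaves compound 3 unresolved from compound 1 as well, while the step of a number 0.39 log units lower from compound 1 to compound 2 (beyond the scatter) still separates the hydrogen and isopropyl compounds. At this position, ethyl therefore cannot be assigned to either end of that measured step, and no measurement available here accounts for any of these steps.

As far as these compounds go, how a propyl chain, a cyclopropyl ring or a hydroxyethyl group on the amine nitrogen would read in this assay stays open, and with only hydrogen, ethyl and isopropyl at this position, no trend with chain size can be drawn. From the compounds shown here alone, the nitrile is common to all three compounds, so the effect of another group in its place also stays open.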